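Working notes on the step from compound 2 to compound 4

This account rests on a few compounds, and the source may have more. Where it says the series, first, only, none or still open, it means among the compounds named here.

Measured so far:
compound 1, `CNc1nc(NCc2ccc(N(C)C(C)=O)cc2)cc(-c2ccccn2)n1`, 1180 nM
compound 2, `COCCNc1nc(NCC2CC2)cc(-c2ccccn2)n1`, 2200 nM
compound 3, `CNc1nc(NC2(c3ccc(Cl)cc3)CCC2)cc(-c2ccccn2)n1`, 25 nM

In a functional assay on HEK293 cells for agonist activity at G-protein coupled receptor 39 (Homo sapiens), read by inositol phosphate accumulation (on this read-out lower numbers stand for an effect already at smaller amounts and higher numbers for an effect only at larger amounts of compound), compound 2 gives 2200 nM, the highest of the three numbers; compound 1 sits closest, within the usual scatter, while compound 3 sits far lower, beyond it. Compound 4 `c1ccc(-c2cc(NCC3CC3)ncn2)nc1` is not yet measured. It differs from compound 2 in one place: hydrogen in place of (2-methoxyethyl)amino on an aromatic carbon. Within the data shown here, no measured pair shows the effect of this change, so the expectation rests on the values themselves. The expected step of a 2.7-fold higher number from compound 2 to compound 4 (0.44 log units; beyond the scatter) points toward a higher number, beyond the scatter, since the measured compounds all keep an amino substituent at that carbon. Compound 4 is estimated at 6000 nM, with a range from 1500 nM to 30000 nM.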

Compound 4, half-maximal effective concentration: 22000 nM
Compound 4: middle estimate off by 3.7-fold (0.56 log units), on the low side; the range from low to high includes it.
By their numbers in this assay, from the lowest: compound 3; then compounds 1 and 2 (each within the scatter of the next); then compound 4.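

In this assay, among these compounds, hydrogen in place of (2-methoxyethyl)amino on the aromatic carbon between two ring nitrogen atoms gives a 10-fold higher number from compound 2 to compound 4 (1.00 log units; beyond the scatter) and this is the first one-place comparison. In this pair, the substituent at this carbon matters to the read-out, as the step lies beyond the scatter. No evidence on hand accounts for the step.

From the compounds shown here alone, it remains open how a plain amine, a methyl group or a longer chain at this carbon compares with (2-methoxyethyl)amino. Also open, going by these compounds, is whether the step holds with a group other than (cyclopropylmethyl)amino on the ring.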